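Adding a Second Chloro Group to a Thiourea Inhibitor

A few compounds are considered here, and "the series" means these few. Any claim that something is new, unique, unknown or untested is made for them only; others in the source may bear on it.

Three thioureas carrying a shared indole-bearing core have been tested in an ADME assay on cells for inhibition of Amine oxidase [flavin-containing] A (Homo sapiens), read by spectrophotometry; on this read-out higher numbers stand for weaker inhibition and lower numbers for stronger inhibition. Compound 1 `Oc1ccccc1NC(=S)Nc1ccc2[nH]ccc2c1` gives 39000 nM. Compound 3 `Oc1cc(Cl)ccc1NC(=S)Nc1ccc2[nH]ccc2c1` gives 39000 nM, and the step from compound 1 to compound 3 is no change at the digits printed from compound 1 to compound 3 (within the scatter), the change being (chloro in place of hydrogen on an aromatic carbon). Compound 2 `Oc1ccc(NC(=S)Nc2ccc3[nH]ccc3c2)cc1Cl` gives 58000 nM; how its core differs from the core of compound 1 is not broken down here, so the gap between these two values is simply what the numbers show.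

Compound 4 `Oc1c(Cl)cc(NC(=S)Nc2ccc3[nH]ccc3c2)cc1Cl` has not yet been measured. It differs from compound 2 by chloro in place of hydrogen on an aromatic carbon. Among the compounds with values here, this is the same kind of change as the one from compound 1 to compound 3, but the surroundings differ: in compound 4 the new chloro group sits ortho to a hydroxy group, meta to a chloro group and meta to a large group, whereas in compound 3 it sits meta to a hydroxy group and para to a large group. Because no change at the digits printed from compound 1 to compound 3 (within the scatter), the expected step from compound 2 to compound 4 in this assay is no change at the digits printed from compound 2 to compound 4 (within the scatter). Compound 4 is therefore estimated at 58000 nM, between 25000 nM and 130000 nM.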

Compound 4, half-maximal inhibitory concentration: "not active" (no number reported)
The entry for compound 4 holds no number; no gap can be computed for the estimate.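

Within the data shown here, compound 4 is recorded as "not active" with no number, so no step from compound 2 to compound 4 can be read. No other data here bear on this result. The compounds shown leave open how far compound 4 lies from compound 2, and whether the second chloro group changes inhibition at all.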